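The compounds below may be only part of what the source reports. "The series", "measured", "known", "first", "only" and "open" are said of these compounds alone.

Compound 1 `c1cc(N2CCCCC2)nc(Nc2ccc(Oc3ncnc4sccc34)cc2)n1`: 66.3%
Compound 2 `CN(c1ccc(Oc2ncnc3ccsc23)cc1)c1nccc(N2CCCC2)n1`: 63.6%

In a functional assay on HCT-116 cells (Homo sapiens) for inhibition, read by MTT assay, with a stated time of 72 h, tested at 20 uM (on this read-out lower numbers stand for less inhibition and higher numbers for more inhibition at the one concentration tested (going by the name of the read-out)), compound 2 stands at the bottom of these two numbers, yet compound 1 lies within the scatter of it, so the two show no real difference. Compound 3 `CN(c1ccc(Oc2ncnc3ccsc23)cc1)c1nccc(N2CCc3ccccc3C2)n1` is not yet measured. It differs from compound 2 in one place: 1,2,3,4-tetrahydroisoquinolin-2-yl in place of pyrrolidin-1-yl on an aromatic carbon. Among the compounds with values here, no measured pair covers a change of this kind, so its direction is unknown; a modest step either way is expected. For compound 3 the expected value is 60%, between 35% and 80%. This expectation means a step of a number 3.6 percentage points lower from compound 2 to compound 3 (within the scatter).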

Compound 3, a percentage reported as inhibition, at one concentration (the size of the read-out at that concentration, not a potency): 58.3%
For compound 3 the middle estimate is 1.7 percentage points above the measured one, and the stated range covers the measured number.
By their numbers in this assay, from the lowest: compounds 3, 2 and 1 (each within the scatter of the next).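

Replacing pyrrolidin-1-yl with 1,2,3,4-tetrahydroisoquinolin-2-yl on this aromatic carbon gives a number 5.3 percentage points lower from compound 2 to compound 3 (within the scatter) in this assay. The position therefore accepts a group carrying an added aromatic ring of carbon only, with no real change in the read-out. Nothing available explains this result.

As far as these compounds go, whether a morpholin-4-yl group or an open-chain dimethylamino group would also hold the read-out remains open. A reading at one concentration also leaves open whether compound 2 and compound 3 match in potency.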